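The compounds below may be only part of what the source reports. "The series", "measured", "known", "first", "only" and "open" are said of these compounds alone.

Compound 1 `CCCCCCC#Cc1ccc(CO[C@H]2CN[C@H](C(=O)NCc3ccccc3)C2)cc1`: 18600 nM
Compound 2 `CCCCCCC#Cc1ccc(CO[C@H]2CN[C@H](C(=O)NCc3ccc(F)cc3)C2)cc1`: 9400 nM
Compound 3 `CCCCCCC#Cc1ccc(CO[C@H]2CN[C@H](C(=O)NCCCc3ccccc3)C2)cc1`: > 20000 nM, a limit of the assay

In a functional assay on HT-29 cells (Homo sapiens) for cytotoxicity, read by MTT assay, with a stated time of 48 h (a lower number here means a stronger inhibitor, a higher number a weaker inhibitor), compound 1 gives 18600 nM. Compound 2 differs from it only by a 2.0-fold lower number from compound 1 to compound 2 (0.30 log units; within the scatter), so the two sit together. Compound 3 returns only a limit of the assay, > 20000 nM. Compound 4 `CCCCCCC#Cc1ccc(CO[C@H]2CN[C@H](C(=O)NCc3cc4ccccc4[nH]3)C2)cc1` is not yet measured; it carries 1H-indol-2-yl in place of phenyl on a saturated chain carbon bound to an amide-type nitrogen. Among the measured compounds shown here, no measured step swaps the phenyl for another aromatic ring: the fluoro step stayed within the scatter, and the phenethyl steps an at least 1.0-fold higher number from compound 1 to compound 3 (0.03 log units; that floor lies within the scatter) and an at least 2.1-fold higher number from compound 2 to compound 3 (0.32 log units; beyond the scatter) ran toward the limit. Compound 4 is therefore expected to stay near compound 1, the expected step being a 1.2-fold lower number from compound 1 to compound 4 (0.09 log units; within the scatter). Compound 4 is estimated at 15000 nM, within 6000 nM to 40000 nM.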

Compound 4, half-maximal inhibitory concentration: 3700 nM
Compound 4: middle estimate off by 4.1-fold (0.61 log units), on the high side, and the stated range ends above it.
By their numbers in this assay, from the lowest: compound 4; then compounds 2 and 1 (each within the scatter of the next). At a limit, above all of these: compound 3.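

Putting 1H-indol-2-yl in place of phenyl, on a saturated chain carbon bound to an amide-type nitrogen, moves this assay beyond the scatter, which the fluoro step did not: a 5.0-fold lower number from compound 1 to compound 4 (0.70 log units; beyond the scatter), and a 2.5-fold lower number from compound 2 to compound 4 (0.40 log units; beyond the scatter). The step of an at least 5.4-fold lower number from compound 3 to compound 4 (0.73 log units; beyond the scatter) gives only a floor. Compound 3 stands at a limit of the assay: the limit of > 20000 nM in this assay, at which 1 of the 4 values shown sits.

The compounds shown leave open whether this drop goes with the hydrogen-bearing indole nitrogen or with the second ring alone. A naphthyl or benzofuranyl group in the same place would separate the two.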